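A few compounds are considered here, and "the series" means these few. Any claim that something is new, unique, unknown or untested is made for them only; others in the source may bear on it.

Measured in a functional assay on T47D cells (Breast, Homo sapiens) for inhibition; on this read-out lower numbers stand for stronger inhibition of growth and higher numbers for weaker inhibition of growth:
- Compound 1 `Cc1cc(-c2nc3c(F)cccc3s2)ccc1N`: < 10 nM, a limit of the assay
- Compound 2 `Nc1ccc(-c2nc3cc(F)ccc3s2)cc1`: 260 nM
- Compound 3 `Nc1ccc(-c2nc3cc(F)ccc3s2)cc1Cl`: 40 nM

Of the two values that are actual numbers, compound 3 holds the lower, and compound 2 the higher. Compound 4 `Nc1ccc(-c2nc3cc(F)ccc3s2)cc1I` differs from compound 3 by iodo in place of chloro on an aromatic carbon, with iodo in place of chloro on an aromatic carbon, ortho to an amino group. For the measured compounds named here, one measured step bears on this carbon: a 6.5-fold lower number from compound 2 to compound 3 (0.81 log units; beyond the scatter), where chloro replaced hydrogen. Going by the values given here, no measured step covers iodo, so the swap of chloro for iodo is expected to leave this assay largely unchanged, with no shift beyond the scatter. The expected step is a 1.3-fold lower number from compound 3 to compound 4 (0.12 log units; within the scatter). Compound 4 is estimated at 30 nM, with an expected range of 10 nM to 120 nM.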

Compound 4, concentration for 50% growth inhibition: 130 nM
Compound 4: the middle estimate sits 4.3-fold (0.64 log units) below what was measured, outside the stated range (above it).
By their numbers in this assay, from the lowest: compound 3; then compounds 4 and 2 (each within the scatter of the next). At a limit, below all of these: compound 1.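

In this assay the gain seen with chloro on this carbon, ortho to an amino group, does not carry over to iodo: the change shows a 3.3-fold higher number from compound 3 to compound 4 (0.51 log units; beyond the scatter) and so the choice of halogen matters here. Set against hydrogen, iodo gives a 2.0-fold lower number from compound 2 to compound 4 (0.30 log units; within the scatter) and so leaves no clear gain over compound 2. Nothing shown accounts for this difference between the two halogens. Going by these compounds, whether bromo on this carbon would stay close to compound 3 or to compound 4 remains open, as does the effect of a methoxy group there.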